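Alkoxy shift on the aryl hydrazone of a sulfonamide

The source may report more compounds than this note shows. Statements on the series, on what has been measured and on what is new or still open speak of the compounds shown alone.

Compound 1 `O=C(N/N=C/c1ccccc1O)c1cccc(S(=O)(=O)N2CCOCC2)c1`: 14400 nM
Compound 2 `COc1ccc(/C=N/NC(=O)c2cccc(S(=O)(=O)N3CCOCC3)c2)c(O)c1`: 2790 nM

In a functional assay on ECa-109 cells for antiproliferative activity against ECa-109 cell line (Homo sapiens), read by MTT assay, with a stated time of 72 h (on this read-out higher numbers stand for weaker inhibition and lower numbers for stronger inhibition), compound 2 holds the lowest of the two numbers, with compound 1 giving the higher one, a step of a 5.2-fold lower number from compound 1 to compound 2 (0.71 log units; beyond the scatter). Compound 3 `CCOc1cccc(/C=N/NC(=O)c2cccc(S(=O)(=O)N3CCOCC3)c2)c1O` differs from compound 2 by 3-ethoxy-2-hydroxyphenyl in place of 2-hydroxy-4-methoxyphenyl on a carbon with a double bond to nitrogen. Within the data shown here, the one measured step, which added a methoxy group, bears only loosely on this change, since an alkoxy group is kept rather than gained. Compound 3 is therefore expected to stay near compound 2, a step of a 1.3-fold higher number from compound 2 to compound 3 (0.10 log units; within the scatter), with an estimate of 3500 nM and a range of 1000 nM to 12000 nM.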

Compound 3, half-maximal inhibitory concentration: 16500 nM
Compound 3: middle estimate off by 4.7-fold (0.67 log units), on the low side; the whole stated range lies below it.
By their numbers in this assay, from the lowest: compound 2; then compounds 1 and 3 (each within the scatter of the next).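

In this assay, keeping an alkoxy group does not keep the gain: 3-ethoxy-2-hydroxyphenyl in place of 2-hydroxy-4-methoxyphenyl gives a 5.9-fold higher number from compound 2 to compound 3 (0.77 log units; beyond the scatter). Ethoxy in place of hydrogen gives only a 1.1-fold higher number from compound 1 to compound 3 (0.06 log units; within the scatter), so the gain seen with methoxy in compound 2 is absent in compound 3. Nothing measured here accounts for this difference. Going by these compounds, it remains open whether the ethoxy chain or its place on the ring decides the result, and whether a longer chain such as butoxy or an amine such as dimethylamino would match compound 2.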